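Adding a chloro to the core of compound 1

The compounds below may be only part of what the source reports. "The series", "measured", "known", "first", "only" and "open" are said of these compounds alone.

Within the data shown here, compound 1 `O=S(=O)(/C=C/c1ccc(Cl)cc1Cl)Cc1ccc(Nc2ncnc3ccccc23)cc1` gives 14000 nM in a functional assay on SW-620 cells (Homo sapiens) (on this read-out lower numbers stand for stronger inhibition of growth and higher numbers for weaker inhibition of growth), the lower of the two numbers measured so far. Compound 2 `O=S(=O)(/C=C/c1ccc(C(F)(F)F)cc1F)Cc1ccc(Nc2ncnc3ccccc23)cc1` gives 100000 nM in this assay. Compound 3 `O=S(=O)(/C=C/c1ccc(Cl)cc1Cl)Cc1ccc(Nc2ncnc3cc(Cl)ccc23)cc1` has not been measured and differs from compound 1 by one change in the shared core: chloro in place of hydrogen on an aromatic carbon. The new chloro stands on an aromatic carbon of a six-membered aromatic ring of carbon only, part of a fused system of two rings.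

Among the measured compounds shown here, the only measured step, a 7.1-fold higher number from compound 1 to compound 2 (0.85 log units; beyond the scatter), replaced 2,4-dichlorophenyl with 2-fluoro-4-(trifluoromethyl)phenyl, a change in a different place. It shows how far one change can move this read-out, but it gives no direction for a chloro on the core. A small step is therefore expected, and the estimated step is a 1.2-fold lower number from compound 1 to compound 3 (0.07 log units; within the scatter). The expected value for compound 3 is 12000 nM, with a range of 4000 nM to 40000 nM.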

Compound 3, concentration for 50% growth inhibition: > 100000 nM
Compound 3: only a limit was reported; the forecaster's own chance of this, stated with the estimate: 10%; middle value at least 8.3-fold (0.92 log units) from the limit.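

At this aromatic carbon of the shared core, a single chloro in place of hydrogen is not a neutral change: in this assay there is an at least 7.1-fold higher number from compound 1 to compound 3 (0.85 log units; beyond the scatter), a weakening of growth inhibition beyond the usual scatter. Among these compounds, the earlier step, a 7.1-fold higher number from compound 1 to compound 2 (0.85 log units; beyond the scatter), concerned the substituted phenyl group, so this is the first sign that the core also responds to a change of one atom. For compound 3, > 100000 nM is a limit and not a number, so the step gives only the smallest size the change can have: the limit of > 100000 nM in this assay, at which 1 of the 3 values shown sits.

The compounds shown leave open whether this loss belongs to chloro itself or would follow any group at this carbon. A fluoro, a methoxy or an amine here could separate those two readings, and so could a chloro on another carbon of the same ring.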